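Thiazolyl for trifluoromethyl: what compound 4 should show

The source may report more compounds than this note shows. Statements on the series, on what has been measured and on what is new or still open speak of the compounds shown alone.

Three compounds carry numbers in an assay for inhibition of protein disulfide-isomerase (Homo sapiens), with a stated time of 1 h; on this read-out higher numbers stand for weaker inhibition and lower numbers for stronger inhibition. Compound 1 `Oc1c(C(c2ccc(F)cc2)N2CCCCC2)ccc2cnccc12` gives 610 nM in this assay. Compound 3 `Oc1c(C(c2ccc(F)cc2)N2CCCCC2)ccc2ccoc12` gives 560 nM. Compound 2 `Oc1ccc2[nH]ncc2c1C(c1ccc(C(F)(F)F)cc1)N1CCCCC1` gives 710 nM. Compound 2 holds the highest of the three numbers, yet its gaps to compound 1 and to compound 3 both lie within the scatter, so the three stand together and none is set apart.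

Compound 4 `Oc1ccc2[nH]ncc2c1C(c1ccc(-c2nccs2)cc1)N1CCCCC1` awaits measurement. It differs from compound 2 in one place: 1,3-thiazol-2-yl in place of trifluoromethyl on an aromatic carbon, the place being on an aromatic carbon of a six-membered aromatic ring of carbon only, para to a large group. Among the compounds with values here, no measured pair in this set makes that exchange, so no step is available to lean on. Since the measured compounds sit close together, only a small move is expected, if any, with a slight lean toward a lower number. The expected step from compound 2 to compound 4 is a 1.4-fold lower number from compound 2 to compound 4 (0.15 log units; within the scatter). Compound 4 is expected to give 500 nM in this assay, with a range from 150 nM to 1600 nM.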

Compound 4, half-maximal inhibitory concentration: 340 nM
Compound 4: the middle estimate sits 1.5-fold (0.17 log units) above what was measured; the measured number falls inside the stated range.
By their numbers in this assay, from the lowest: compounds 4, 3, 1 and 2 (each within the scatter of the next, the first and the last beyond it).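

In this assay, within the data shown here, 1,3-thiazol-2-yl in place of trifluoromethyl gives a 2.1-fold lower number from compound 2 to compound 4 (0.32 log units; beyond the scatter), the only one-place step available so far. The place, on an aromatic carbon of a six-membered aromatic ring of carbon only, para to a large group, therefore accepts a five-membered aromatic ring in place of a group with no ring, and the number moves down rather than up. Nothing measured here bears on the origin of this step.

A single exchange cannot show whether the step belongs to 1,3-thiazol-2-yl in particular or to aromatic rings at this place in general; phenyl, pyridin-2-yl or 1,3-oxazol-2-yl there would separate the two readings. From the compounds shown here alone, whether 1,3-thiazol-2-yl gives a like step on the core of compound 1 or compound 3 also remains open.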